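The source may hold more compounds than are shown below. What is called first, only, known or untested is meant among the compounds shown, and "the series" means these compounds.

Working notes on the series. Compound 1 `COc1cccc(OC)c1OCCNCCOc1ccccc1OCc1ccccc1` gives 193000 nM in a functional assay on PC-3 cells (Homo sapiens) for cytotoxicity, read by sulforhodamine B assay; on this read-out higher numbers stand for lower toxicity in this test and lower numbers for higher toxicity in this test. Compound 2 `COc1ccccc1COc1ccccc1OCCNCCOc1c(OC)cccc1OC` gives 100000 nM in this assay, the lower of the two numbers shown, although the step of a 1.9-fold lower number from compound 1 to compound 2 (0.29 log units; within the scatter) is within the scatter. Compound 3 `COc1cccc(OC)c1OCCNCCOc1ccccc1OCc1ccc(OC(C)C)cc1` carries 4-isopropoxyphenyl in place of 2-methoxyphenyl on a saturated chain carbon bound to an oxygen on an aromatic ring. Among the compounds with values here, no measured step touches the benzyl group; the only step available, a 1.9-fold lower number from compound 1 to compound 2 (0.29 log units; within the scatter), was small, so no shift beyond the scatter is expected. The estimate for compound 3 in this assay is 100000 nM, with a range from 30000 nM to 300000 nM. The expected step is no change at the digits printed from compound 2 to compound 3 (within the scatter).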

Compound 3, concentration lethal to 50% of the cells: 63100 nM
Compound 3: middle estimate off by 1.6-fold (0.20 log units), on the high side; the range from low to high includes it.
By their numbers in this assay, from the lowest: compounds 3, 2 and 1 (each within the scatter of the next, the first and the last beyond it).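

In this assay, the exchange of 2-methoxyphenyl for 4-isopropoxyphenyl on a saturated chain carbon bound to an oxygen on an aromatic ring gives a 1.6-fold lower number from compound 2 to compound 3 (0.20 log units; within the scatter) and so separates neither compound. Adding an isopropoxy group gives a 3.1-fold lower number from compound 1 to compound 3 (0.49 log units; beyond the scatter) as the first modest shift beyond the scatter in the series. No available evidence accounts for either step. Going by these compounds, whether isopropoxy is specifically required stays open, as does the effect of an amine or a carboxylic acid in its place.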